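Chloro to Methyl: Compound 4 Expected Near Compound 1

The source may hold more compounds than are shown below. What is called first, only, known or untested is meant among the compounds shown, and "the series" means these compounds.

Of the compounds shown here, three sharing one core have been measured in a functional assay on MCF7 cells (Homo sapiens) for cytotoxicity, read by MTT assay, with a stated time of 48 h; a lower number here means a stronger inhibitor, a higher number a weaker inhibitor. Compound 1 `Nc1cc(-c2cnc3[nH]cc(-c4ccncc4)c3c2)ccc1Cl` gives 12000 nM; compound 2 `Nc1cc(NS(=O)(=O)c2ccccc2)cc(-c2cnc3[nH]cc(-c4ccncc4)c3c2)c1` gives 8800 nM; compound 3 `Cc1ccc(S(=O)(=O)Nc2cc(N)cc(-c3cnc4[nH]cc(-c5ccncc5)c4c3)c2)cc1` gives 10400 nM. The number for compound 1 is nominally the highest of the three, yet its distances to compound 3 and to compound 2 both lie within the scatter. Compound 4 `Cc1ccc(-c2cnc3[nH]cc(-c4ccncc4)c3c2)cc1N` arises from compound 1 by methyl in place of chloro on an aromatic carbon. For the measured compounds named here, the only measured single change is a 1.2-fold higher number from compound 2 to compound 3 (0.07 log units; within the scatter), a methyl in place of hydrogen, which shows no effect beyond the scatter; no measured step exchanges a chloro for a methyl, so the change to compound 4 is uncharted. The expected step is therefore no change at the digits printed from compound 1 to compound 4 (within the scatter), nothing beyond the scatter. Compound 4 is estimated to give 12000 nM in this assay, within 5000 nM to 30000 nM.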

Compound 4, half-maximal inhibitory concentration: 2800 nM
For compound 4 the middle estimate is 4.3-fold (0.63 log units) above the measured one, and the stated range ends above it.
By their numbers in this assay, from the lowest: compound 4; then compounds 2, 3 and 1 (each within the scatter of the next).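

In this assay, for the compounds shown here, the place ortho to an amino group and para to a large group responds to the exchange of methyl for chloro, with a 4.3-fold lower number from compound 1 to compound 4 (0.63 log units; beyond the scatter) as the first step beyond the scatter. Going by these compounds alone, the only earlier step, a 1.2-fold higher number from compound 2 to compound 3 (0.07 log units; within the scatter), was a methyl for hydrogen elsewhere and stayed within it. Nothing available here accounts for the gain.

What the compounds shown leave open is how hydrogen, fluoro, methoxy, an amine or a longer chain such as ethyl would fare at this place, and whether methyl is the limit of the trend.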